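Swapping the Trichlorophenyl Ester for a Methoxyphenyl Ester

A few compounds are considered here, and "the series" means these few. Any claim that something is new, unique, unknown or untested is made for them only; others in the source may bear on it.

Measured compounds in a functional assay on M21 cells (Homo sapiens) for antiproliferative activity, read by sulforhodamine B assay, with a stated time of 48 h; on this read-out higher numbers stand for weaker inhibition and lower numbers for stronger inhibition:
compound 1 `CN1CCN(c2ccc(S(=O)(=O)Oc3cc(Cl)c(Cl)cc3Cl)cc2)C1=O` — 420 nM
compound 2 `Cc1ccc(OS(=O)(=O)c2ccc(N3CCN(C)C3=O)cc2)cc1` — > 100000 nM
compound 3 `CCCN1CCN(c2ccc(S(=O)(=O)Oc3cc(Cl)c(Cl)cc3Cl)cc2)C1=O` — 15000 nM

Compound 3 holds the higher of the two numbers; the move is a 36-fold higher number from compound 1 to compound 3 (1.55 log units; beyond the scatter), brought about by ethyl in place of hydrogen on the saturated chain carbon bound to the ring amide-type nitrogen. Compound 2 reaches only the limit of the assay at > 100000 nM; that is a limit, not a number. Compound 4 `CCCN1CCN(c2ccc(S(=O)(=O)Oc3ccc(OC)cc3)cc2)C1=O` differs from compound 3 by 4-methoxyphenyl in place of 2,4,5-trichlorophenyl on an oxygen. Going by the values given here, no measured step covers this change. Among the compounds with values here, the only hint is that compound 1 carries the 2,4,5-trichlorophenyl and gives a number, while compound 2, which lacks it, ends at the limit (the limit of > 100000 nM in this assay, at which 1 of the 3 values shown sits). Compound 3 already starts high, so compound 4 is expected to move further toward the limit. The expected step for compound 4 is a 6.7-fold higher number from compound 3 to compound 4 (0.82 log units; beyond the scatter), an upward move meaning weaker inhibition. Compound 4 is therefore estimated at 100000 nM, with a range from 20000 nM to 300000 nM, and it may come out as a limit rather than a number.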

Compound 4, half-maximal inhibitory concentration: 23000 nM
Compound 4: the middle estimate sits 4.3-fold (0.64 log units) above what was measured; measured number inside the range.
By their numbers in this assay, from the lowest: compound 1; then compounds 3 and 4 (each within the scatter of the next). At a limit, above all of these: compound 2.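

In this assay, the exchange on the oxygen bound to the sulfonyl sulfur comes to a 1.5-fold higher number from compound 3 to compound 4 (0.19 log units; within the scatter). On the core of compound 3, then, a measured number does not depend on the 2,4,5-trichlorophenyl: compound 4 carries the 4-methoxyphenyl, has no chlorine, and still gives a number rather than a limit. Compound 2 alone stays at a limit, which is not a number: the limit of > 100000 nM in this assay, at which 1 of the 4 values shown sits.

As far as these compounds go, the exchange can be read only on the core of compound 3, where the numbers are already high, so what 4-methoxyphenyl would do on the core of compound 1 stays open. Also open, from the compounds shown here alone, is how a phenyl ring carrying an amine or a carboxylic acid would behave on this oxygen.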